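A swapped piperidine on compound 2

The source may hold more compounds than are shown below. What is called first, only, known or untested is meant among the compounds shown, and "the series" means these compounds.

In a functional assay on NCI-H460 cells (Homo sapiens) for inhibition, read by sulforhodamine B assay, with a stated time of 72 h (a lower number here means a stronger inhibitor, a higher number a weaker inhibitor), compound 1 `CC(C)c1cc(-n2nncc2-c2ccc(CN3CCN(c4ccccc4)CC3)cc2)c(O)cc1O` gives 520 nM while compound 2 `CCNC(=O)c1nnn(-c2cc(C(C)C)c(O)cc2O)c1-c1ccc(CN2CCC[C@@H](O)C2)cc1` gives 52 nM as the lower of the two numbers, a gap beyond the scatter of repeated measurements. Compound 3 `CCNC(=O)c1nnn(-c2cc(C(C)C)c(O)cc2O)c1-c1ccc(CN2CCC(N(C)C)CC2)cc1` carries 4-(dimethylamino)piperidin-1-yl in place of 3-hydroxypiperidin-1-yl on a saturated chain carbon bound to an aromatic carbon, a swap counted as 4-(dimethylamino)piperidin-1-yl in place of 3-hydroxypiperidin-1-yl on a saturated chain carbon bound to an aromatic carbon against compound 2. Among the compounds with values here, no measured pair shows this swap alone, so in this assay a step within the scatter is expected, with no clear direction. The expected step of a 1.2-fold higher number from compound 2 to compound 3 (0.06 log units; within the scatter) is small. For compound 3 the estimated value is 60 nM (expected range 20 nM to 180 nM).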

Compound 3, half-maximal inhibitory concentration: 120 nM
The estimate for compound 3 lay 2.0-fold (0.30 log units) below the measured number; the measured number falls inside the stated range.
By their numbers in this assay, from the lowest: compound 2; then compound 3; then compound 1.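

In this assay, the swap of 3-hydroxypiperidin-1-yl for 4-(dimethylamino)piperidin-1-yl gives a 2.3-fold higher number from compound 2 to compound 3 (0.36 log units; beyond the scatter). Within the data shown here, this shows that the group on this saturated chain carbon bound to an aromatic carbon can shift the number, though the step is modest and compound 3 remains well within the range of the earlier compounds. Nothing measured here gives a reason for this step.

As far as these compounds go, the hydroxyl leaves and the dimethylamino group enters in one swap, so their separate shares stay open. From the compounds shown here alone, how a morpholine ring or 3-(dimethylamino)piperidin-1-yl would read at this place also stays open.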